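The source may report more compounds than this note shows. Statements on the series, on what has been measured and on what is new or still open speak of the compounds shown alone.

Compound 1 `COc1ccccc1/C=C/C(=O)/C=C/c1ccc(OCc2cn(CCOc3cc(=O)oc4ccccc34)nn2)c(OC)c1` holds the higher of the two measurements made so far: in a functional assay on COLO 205 cells (Homo sapiens) for inhibition, read by sulforhodamine B assay, with a stated time of 48 h, tested at 50 uM (on this read-out lower numbers stand for less inhibition of growth and higher numbers for more inhibition of growth at the one concentration tested), compound 1 gives 67%, while compound 2 `COc1ccccc1/C=C/C(=O)/C=C/c1ccc(OCc2cn(CCCCOc3cc(=O)oc4ccccc34)nn2)c(OC)c1` gives 47%, a gap beyond the usual scatter. Compound 3 `COc1ccc(/C=C/C(=O)/C=C/c2ccc(OCc3cn(CCOc4cc(=O)oc5ccccc45)nn3)c(OC)c2)cc1OC` has not yet been tested. It differs from compound 1 by 3,4-dimethoxyphenyl in place of 2-methoxyphenyl on a double-bonded chain carbon bound to a double-bonded chain carbon. Within the data shown here, no measured pair shows this change, so in this assay the step is expected to be small, in either direction or none beyond the scatter. The result for compound 3 is estimated at 62%, between 42% and 80%. The expected step is a number 5 percentage points lower from compound 1 to compound 3 (within the scatter).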

Compound 3, percent growth inhibition at one concentration: 80%
Estimate against measurement, compound 3: 18 percentage points below, within the range that was stated.
By their numbers in this assay, from the lowest: compound 2; then compound 1; then compound 3.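

In this assay, 3,4-dimethoxyphenyl in place of 2-methoxyphenyl on a double-bonded chain carbon bound to a double-bonded chain carbon gives a number 13 percentage points higher from compound 1 to compound 3 (beyond the scatter) in this series. This shows that the read-out responds to the aryl group at this position, which the earlier pair, differing only in its other chain, could not show. No evidence at hand accounts for this step. From the compounds shown here alone, whether the step would hold on the longer chain of compound 2 stays open. So does what an amine or a carboxylic acid on that phenyl ring would give.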